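A silicon-bearing group gives way to diisopropylcarbamoyl

A few compounds are considered here, and "the series" means these few. Any claim that something is new, unique, unknown or untested is made for them only; others in the source may bear on it.

Among the compounds with values here, in a functional assay on HL-60 cells (Homo sapiens) for antiproliferative activity, read by MTT assay, with a stated time of 48 h (on this read-out higher numbers stand for weaker inhibition and lower numbers for stronger inhibition), compound 1 `CC(C)=CCC[C@]1(C)/C=C/[C@@H](OC(=O)C=C(C)C)[C@](C)(O)/C=C/C(=O)/C(C[Si](C)(C)C(C)(C)C)=C\C1` gives 2770 nM, the higher of the two numbers measured so far. Compound 2 `CC(C)=CCC[C@]1(C)/C=C/[C@@H](OC(=O)C=C(C)C)[C@](C)(O)/C=C/C(=O)/C(COC(=O)c2ccc([N+](=O)[O-])cc2)=C\C1` gives 830 nM. Compound 3 `CC(C)=CCC[C@]1(C)/C=C/[C@@H](OC(=O)C=C(C)C)[C@](C)(O)/C=C/C(=O)/C(C(=O)N(C(C)C)C(C)C)=C\C1` has not yet been measured, and its change is a group of 9 heavy atoms (7 carbon, 1 nitrogen, 1 oxygen; no ring) in place of a group of 8 heavy atoms (7 carbon, 1 silicon; no ring), on a double-bonded ring carbon. Here diisopropylcarbamoyl enters on a double-bonded ring carbon. Within the data shown here, only one measured step bears on this: a 3.3-fold lower number from compound 1 to compound 2 (0.52 log units; beyond the scatter). That step also removes the silicon-bearing group, but its entering group holds an aromatic ring and stands on a saturated chain carbon, so it is an imperfect guide. A modest move toward a lower number in this assay is therefore expected, with wide uncertainty. The estimated step is a 2.1-fold lower number from compound 1 to compound 3 (0.33 log units; beyond the scatter). Compound 3 is expected at 1300 nM, within an estimated range of 500 nM to 3200 nM.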

Compound 3, half-maximal inhibitory concentration: 12700 nM
For compound 3 the middle estimate is 9.8-fold (0.99 log units) below the measured one; measured number above the stated range.
By their numbers in this assay, from the lowest: compound 2; then compound 1; then compound 3.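

In this assay, within the data shown here, the change on this double-bonded ring carbon runs opposite to the only earlier step: compound 3 shows a 4.6-fold higher number from compound 1 to compound 3 (0.66 log units; beyond the scatter), whereas compound 2 showed a 3.3-fold lower number from compound 1 to compound 2 (0.52 log units; beyond the scatter). Removing the silicon-bearing group therefore does not bring a lower number by itself, and across these compounds the direction depends on what enters. Nothing available accounts for the higher number with diisopropylcarbamoyl.

The compounds shown leave open whether a dimethylcarbamoyl group, a carboxylic acid or an aminomethyl group on the same ring carbon would give a number nearer that of compound 1 or compound 3. They also leave open how diisopropylcarbamoyl would fare on a saturated chain carbon bound to the double-bonded ring carbon, where the change in compound 2 lies.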